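The source may hold more compounds than are shown below. What is called first, only, known or untested is meant among the compounds shown, and "the series" means these compounds.

Measured compounds in a functional assay on NALM-6 cells (Homo sapiens) for cytotoxicity, read by MTT assay, with a stated time of 48 h; on this read-out higher numbers stand for weaker inhibition and lower numbers for stronger inhibition:

Compound 1, `C=C1C(=O)OC(C)CC1c1ccc([N+](=O)[O-])cc1`, gives 3420 nM.
Compound 2, `C=C1C(=O)OC(C)CC1C1CCCCC1`, gives 15800 nM.
Compound 3, `C=C1C(=O)O[C@H](C)[C@@H]1c1ccc([N+](=O)[O-])cc1`, gives 3770 nM.

Compound 3 has the second highest of the three numbers in this assay. Its nearest neighbour is compound 1, whose number is only slightly lower and lies within the scatter of repeated measurements, so no order between the two can be read. The furthest is compound 2, whose number is higher by a margin that lies beyond the scatter.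

Compound 4, `C=C1C(=O)O[C@H](C)[C@@H]1c1ccc(OC)cc1`, is not yet measured. It differs from compound 3 in one place: methoxy in place of nitro on an aromatic carbon. Among the compounds with values here, no pair of measured compounds shows this change, so there is no measured step to lean on, and the expectation rests on compound 3 alone. A modest step towards a higher number, weaker inhibition, is expected in this assay, a 1.6-fold higher number from compound 3 to compound 4 (0.20 log units; within the scatter), though a step no larger than the scatter is also plausible. For compound 4 the estimated value in this assay is 6000 nM, with a likely range from 2000 nM to 18000 nM.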

Compound 4, half-maximal inhibitory concentration: 5590 nM
The estimate for compound 4 lay 1.1-fold (0.03 log units) above the measured number, and the stated range covers the measured number.
By their numbers in this assay, from the lowest: compounds 1, 3 and 4 (each within the scatter of the next); then compound 2.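

In this assay methoxy in place of nitro on the aromatic carbon gives a 1.5-fold higher number from compound 3 to compound 4 (0.17 log units; within the scatter) and so leaves the two numbers indistinguishable. Within the data shown here, until now no measured step spoke for this position; this pair shows that, on the core of compound 3, the nitro group is not needed to keep the number within the scatter, even though methoxy has fewer heavy atoms and hydrogen-bond acceptors. No measured property of either group bears on this result, so the pair offers no explanation for it.

On these data alone, whether an amine, a carboxylic acid or a chlorine atom on the same aromatic carbon would stay level with compound 3 or move beyond the scatter remains open. So does whether methoxy in place of nitro gives a similar step on the core of compound 1.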